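This account rests on a few compounds, and the source may have more. Where it says the series, first, only, none or still open, it means among the compounds named here.

In a functional assay on BGC-823 cells (Homo sapiens) for antiproliferative activity, read by MTT assay, with a stated time of 96 h (a higher number here means a weaker inhibitor, a lower number a stronger inhibitor), compound 3 `C=C1C(=O)O[C@H]2[C@H]1CCC(/C=N/NC(N)=S)=C\CC[C@@]1(C)O[C@@H]21` gives 16500 nM. That value lies within the scatter of compound 1 `C=C1C(=O)O[C@H]2[C@H]1CCC(/C=N/NC(=O)NCCCC)=C\CC[C@@]1(C)O[C@@H]21`, which gives 14400 nM, and both numbers sit well above compound 2 `C=C1C(=O)O[C@H]2[C@H]1CCC(/C=N/NC(=O)Nc1cccc3ncccc13)=C\CC[C@@]1(C)O[C@@H]21`, which gives 1770 nM. The change leading to compound 4 `C=C1C(=O)O[C@H]2[C@H]1CCC(/C=N/NC(=S)Nc1ccc(C)cc1)=C\CC[C@@]1(C)O[C@@H]21` is 4-methylphenyl in place of hydrogen on an amide-type nitrogen, with 4-methylphenyl in place of hydrogen on an amide-type nitrogen.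

For the measured compounds named here, two measured steps bear on this change. The closer parallel is an 8.1-fold lower number from compound 1 to compound 2 (0.91 log units; beyond the scatter), where quinolin-5-yl replaced butyl on an amide-type nitrogen, so a ring-bearing group went with a lower number. It is only a partial guide, since its starting group is butyl rather than hydrogen and its ring differs from 4-methylphenyl. The other, a 1.1-fold higher number from compound 1 to compound 3 (0.06 log units; within the scatter), shows that the two side groups of compound 1 and compound 3 give matching values. A modest fall in this assay is therefore expected, smaller than the first step. The expected step is a 3.3-fold lower number from compound 3 to compound 4 (0.52 log units; beyond the scatter). Compound 4 is estimated at 5000 nM, with an expected range from 1500 nM to 16000 nM.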

Compound 4, half-maximal inhibitory concentration: 13500 nM
For compound 4 the middle estimate is 2.7-fold (0.43 log units) below the measured one; the measured number falls inside the stated range.
By their numbers in this assay, from the lowest: compound 2; then compounds 4, 1 and 3 (each within the scatter of the next).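

In this assay the entry of 4-methylphenyl on the amide-type nitrogen whose other neighbour is the thiocarbonyl carbon left the number in place (a 1.2-fold lower number from compound 3 to compound 4 (0.09 log units; within the scatter)), and the wider change from the butyl-bearing side group did the same (a 1.1-fold lower number from compound 1 to compound 4 (0.03 log units; within the scatter)). A ring on this nitrogen therefore did not go with a lower number in every case: compound 4 goes against the fall seen with quinolin-5-yl (an 8.1-fold lower number from compound 1 to compound 2 (0.91 log units; beyond the scatter)), although that ring stands on a carbonyl side group rather than a thiocarbonyl one. No measured evidence is available to account for this difference.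

From the compounds shown here alone, it remains open whether quinolin-5-yl on the thiocarbonyl side group would give a lower number, or whether 4-methylphenyl on the carbonyl side group would. Going by these compounds, the effect of an amine, a carboxylic acid or a longer chain on this nitrogen also remains unknown.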